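The compounds below may be only part of what the source reports. "The series", "measured", "known", "first", "only" and "open" are said of these compounds alone.

Measured so far in an assay for inhibition of Fatty-acid amide hydrolase 1 (Rattus norvegicus); a higher number here means a weaker inhibitor, a lower number a stronger inhibitor:
compound 1 `COC(=O)c1ccc(-c2cnc(C(=O)CCc3ccc(-c4ccccc4)cc3)o2)nc1` — 2.2 nM
compound 2 `CS(=O)(=O)c1cnc(C(=O)CCc2ccc(-c3ccccc3)cc2)o1` — 1.2 nM
compound 3 `NC(=O)c1cccc(-c2cnc(C(=O)CCc3ccc(-c4ccccc4)cc3)o2)n1` — 1.2 nM

Compound 1 carries the highest of the three numbers, yet neither gap exceeds the scatter: a 1.8-fold lower number from compound 1 to compound 2 (0.26 log units; within the scatter), a 1.8-fold lower number from compound 1 to compound 3 (0.26 log units; within the scatter), and between the other two no change at the digits printed from compound 2 to compound 3 (within the scatter). All three steps vary the substituent on the shared core, not the phenyl end of the chain.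

Compound 4 `COC(=O)c1ccc(-c2cnc(C(=O)CCc3ccc(COc4ccccc4)cc3)o2)nc1` changes that other end: phenoxymethyl in place of phenyl on an aromatic carbon. Among the measured compounds shown here, no measured step touches this part of the molecule, so the steps offer no direct guide; they show only that the series so far sits in a narrow band. As a working expectation a modest weakening is assumed, a 2.3-fold higher number from compound 1 to compound 4 (0.36 log units; beyond the scatter), with no change equally plausible. Compound 4 is therefore estimated at 5 nM, range 1.5 nM to 20 nM.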

Compound 4, inhibition constant: 3.5 nM
For compound 4 the middle estimate is 1.4-fold (0.15 log units) above the measured one, and the stated range covers the measured number.
By their numbers in this assay, from the lowest: compounds 2, 3, 1 and 4 (each within the scatter of the next, the first and the last beyond it).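

Among the compounds shown here, the phenyl end of the chain, which the earlier steps left unchanged, now has a step of its own in this assay: phenoxymethyl in place of phenyl gives a 1.6-fold higher number from compound 1 to compound 4 (0.20 log units; within the scatter). At this aromatic carbon, para to a large group, the larger phenoxymethyl with its added oxygen therefore leaves the number within the scatter. No measurement offers an explanation for this result.

On these data alone, whether phenoxymethyl reads the same with methylsulfonyl or 6-carbamoylpyridin-2-yl on the shared core remains open. So does the outcome for an amine, a carboxylic acid or a longer ether chain at this position.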